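Acetyl for dimethylamino on the pendant phenyl

A few compounds are considered here, and "the series" means these few. Any claim that something is new, unique, unknown or untested is made for them only; others in the source may bear on it.

Measured so far:
compound 1 `COc1cc(C)cc(-c2c(-c3ccnc(-c4ccc(N(C)C)cc4)c3)cnn2CC#N)c1`: 54.1 nM
compound 2 `COc1cc(C)cc(-c2nn(CC#N)cc2-c2ccc(-c3cccc(C(C)=O)c3)nc2)c1`: 1170 nM

Within the data shown here, in a functional assay on M14 cells (Homo sapiens) for inhibition, read by sulforhodamine B assay, with a stated time of 48 h (a lower number here means a stronger inhibitor of growth, a higher number a weaker inhibitor of growth), compound 1 gives 54.1 nM, the lowest of the two numbers so far. Among the measured compounds shown here, compound 2 gives 1170 nM, a gap beyond the scatter, but the two differ in more than one place and no single step joins them. Compound 3 `COc1cc(C)cc(-c2c(-c3ccnc(-c4ccc(C(C)=O)cc4)c3)cnn2CC#N)c1` is not yet measured; it differs from compound 1 in one place: acetyl in place of dimethylamino on an aromatic carbon. For the measured compounds named here, no measured pair isolates this exchange. The expected step in this assay is a 3.7-fold higher number from compound 1 to compound 3 (0.57 log units; beyond the scatter), toward a higher number, modest but beyond the scatter. Compound 3 is estimated at 200 nM, with a range from 60 nM to 700 nM.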

Compound 3, concentration for 50% growth inhibition: 1970 nM
Estimate against measurement, compound 3: 9.9-fold (0.99 log units) below; measured number outside the range, above it.
By their numbers in this assay, from the lowest: compound 1; then compounds 2 and 3 (each within the scatter of the next).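

In this assay, among these compounds, acetyl in place of dimethylamino gives a 36-fold higher number from compound 1 to compound 3 (1.56 log units; beyond the scatter), the first single-place reading. This position is therefore sensitive to the group it carries, even though the two groups match in heavy atom count and hydrogen-bond acceptor count. No measurement shown here accounts for the size of this step.

Going by these compounds, it remains open whether a primary amine, a methoxy group or a carboxylic acid at the same place would read closer to compound 1 or to compound 3. Also open, on these data alone, is whether a cyclic amine such as morpholine could stand in for dimethylamino.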